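The compounds below may be only part of what the source reports. "The series", "measured", "known", "first", "only" and "open" are said of these compounds alone.

Measured so far in a functional assay on KYSE-510 cells (Homo sapiens) for antiproliferative activity, read by crystal violet staining, with a stated time of 96 h; a lower number here means a stronger inhibitor of growth, a higher number a weaker inhibitor of growth:
compound 1 `O=S(=O)(NC1=NCCN1C(=S)SN1CCn2c1nsc2=S)c1ccccc1Cl` gives >= 20000 nM; this is a limit of the assay.
compound 2 `O=S(=O)(NC1=NCCN1C(=S)SN1CCn2c1nsc2=S)c1ccc(Cl)cc1` gives >= 20000 nM; this too is a limit of the assay.

Compound 2 thus stands only at a limit, as shown by the limit of >= 20000 nM in this assay, at which 2 of the 2 values shown sit. Among the compounds with values here, the one measured step, a step that the two limits leave unreadable from compound 1 to compound 2, cannot be read from two limits. Compound 3 `O=S(=O)(NC1=NCCN1C(=S)SN1CCn2c1nsc2=S)c1ccc(F)c(Cl)c1` carries the change (3-chloro-4-fluorophenyl in place of 4-chlorophenyl on a sulfonyl sulfur). No readable step bears on this change, so from compound 2 to compound 3 a step of a number no higher from compound 2 to compound 3 (the limit leaves the size open) is expected, none beyond the scatter. For compound 3 in this assay a value of 20000 nM is estimated, between 8000 nM and 40000 nM.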

Compound 3, concentration for 50% growth inhibition: >= 20000 nM
Compound 3 was reported as a limit; the forecaster's own chance of this, stated with the estimate: 80%; the middle value sits exactly at the limit.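

No step between compound 1, compound 2 and compound 3 can be read in this assay, as all three sit at a limit: the limit of >= 20000 nM in this assay, at which 3 of the 3 values shown sit.

The compounds shown leave open how 2-chlorophenyl, 4-chlorophenyl and 3-chloro-4-fluorophenyl on the sulfonyl sulfur rank against one another in this assay.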